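A few compounds are considered here, and "the series" means these few. Any claim that something is new, unique, unknown or untested is made for them only; others in the source may bear on it.

Compound 1 `CNC(=O)/C=C/c1ccc(NC(=O)Nc2ccc(Cl)c(C(F)(F)F)c2)cc1` and compound 2 `CC1CN(C(=O)/C=C/c2ccc(NC(=O)Nc3ccc(Cl)c(C(F)(F)F)c3)cc2)CC(C)O1` share one core and differ only at a carbonyl carbon. In a functional assay on HepG2 cells (Homo sapiens) for inhibition, read by MTT assay, with a stated time of 120 h (on this read-out lower numbers stand for stronger inhibition and higher numbers for weaker inhibition), compound 2 gives 45900 nM, and compound 1 gives 20400 nM. The change methylamino in place of 2,6-dimethylmorpholin-4-yl on a carbonyl carbon made a step of a 2.3-fold lower number from compound 2 to compound 1 (0.35 log units; beyond the scatter). Compound 3 `C/C(=C\C(=O)N1CC(C)OC(C)C1)c1ccc(NC(=O)Nc2ccc(Cl)c(C(F)(F)F)c2)cc1` carries a different core; the difference between the two cores is not broken down here. In this assay compound 3 gives only a limit, > 50000 nM, which is the limit of > 50000 nM in this assay, at which 1 of the 3 values shown sits. Compound 4 `CNC(=O)/C=C(\C)c1ccc(NC(=O)Nc2ccc(Cl)c(C(F)(F)F)c2)cc1` stands to compound 3 as compound 1 stands to compound 2, through the same change (methylamino in place of 2,6-dimethylmorpholin-4-yl on a carbonyl carbon). A step of the same modest size is expected, an at least 1.2-fold lower number from compound 3 to compound 4 (0.09 log units; that floor lies within the scatter), resting on the measured step of a 2.3-fold lower number from compound 2 to compound 1 (0.35 log units; beyond the scatter). Since compound 3 starts from a limit, compound 4 is expected near 40000 nM, within 15000 nM to 100000 nM.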

Compound 4, half-maximal inhibitory concentration: > 50000 nM
Compound 4: a limit, no number; the forecaster's own chance of this, stated with the estimate: 40%; middle value at least 1.2-fold (0.09 log units) from the limit.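

In this assay compound 4 gives only a limit, > 50000 nM, and not a number. Within the data shown here, the one step that can be read is 1-methyl-2-(methylcarbamoyl)ethenyl in place of 2-(methylcarbamoyl)ethenyl on an aromatic carbon, with an at least 2.4-fold higher number from compound 1 to compound 4 (0.38 log units; beyond the scatter). The step between compound 3 and compound 4 cannot be read, so the data neither confirm nor rule out that the change from 2,6-dimethylmorpholin-4-yl to methylamino carries over from the core of compound 1 to the core of compound 4, and both compounds on that core stop at the same limit: the limit of > 50000 nM in this assay, at which 2 of the 4 values shown sit.

As far as these compounds go, it remains open whether any group on the carbonyl carbon of this core would give a readable number in this assay. Dimethylamino or piperazin-1-yl at that place, for example, could test this.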